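A few compounds are considered here, and "the series" means these few. Any claim that something is new, unique, unknown or untested is made for them only; others in the source may bear on it.

In an ADME assay on HEK293 cells (Homo sapiens) for cytotoxicity, read by luminescence, with a stated time of 72 h (a lower number here means that less compound is needed, a higher number that more compound is needed for the effect), compound 3 `CCOC(=O)c1c(-c2cccc(-c3ccccc3)c2)[nH]c2cc(OC)c(F)cc2c1=O` gives > 22000 nM, a limit of the assay and not a number. Compound 1 `CCOC(=O)c1c(-c2cccc(OC)c2)[nH]c2cc(OC)ccc2c1=O` gives > 22000 nM, also a limit. Compound 2 `CCOC(=O)c1c(-c2cccc(OC)c2)[nH]c2cc(OC)c(Cl)cc2c1=O` gives > 22000 nM, again a limit. The next structure is compound 4 `CCOC(=O)c1c(-c2cccc(OC)c2)[nH]c2cc(OC)c(F)cc2c1=O`: methoxy in place of phenyl on an aromatic carbon, with methoxy in place of phenyl on an aromatic carbon, meta to a large group. Going by the values given here, the only measured step, a step that the two limits leave unreadable from compound 1 to compound 2, is a different change and offers no size to carry over. Compound 1, compound 2 and compound 3 share (the limit of > 22000 nM in this assay, at which 3 of the 3 values shown sit), so no step beyond the scatter is expected in either direction in this assay. The expected step is a number no higher from compound 3 to compound 4 (the limit leaves the size open). For compound 4 the estimate is 22000 nM, with an expected range of 14000 nM to 30000 nM.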

Compound 4, half-maximal effective concentration: > 22000 nM
Compound 4: only a limit was reported; the forecaster's own chance of this, stated with the estimate: 88%; the middle value lies on the limit itself.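

Compound 4 set against compound 1, compound 2 or compound 3 gives no readable step, since all of these values are limits and not numbers. The compounds shown leave open what size any of these changes has in this assay: the limit of > 22000 nM in this assay, at which 4 of the 4 values shown sit.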